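This account rests on a few compounds, and the source may have more. Where it says the series, first, only, none or still open, it means among the compounds named here.

Series notes. Values in a functional assay on BGC-823 cells (Homo sapiens) for antiproliferative activity, read by MTT assay, tested at 5 uM; a higher number here means a stronger effect of the compound at the concentration tested, a lower number a weaker effect:

compound 1 `COc1cc(C2=NN(C(C)=O)C(c3ccccc3C(F)(F)F)O2)cc(OC)c1OC` gives 34.8%
compound 2 `COc1cccc(/C=N/NC(=O)c2cc(OC)c(OC)c(OC)c2)c1OC` gives 14.2%
compound 3 `COc1cc(C(=O)N/N=C/c2cc(Cl)cc(Cl)c2)cc(OC)c1OC` gives 9.2%

Compound 1 holds the highest of the three numbers. Compound 2 is the nearest to it and lies lower by a margin beyond the usual scatter; compound 3 lies further below, also beyond the scatter. Compound 4 `COc1cc(C2=NN(C(C)=O)C(c3cccc(C(F)(F)F)c3)O2)cc(OC)c1OC` is not yet measured. It is built from the same atoms as compound 1, joined differently, the change sitting on the phenyl carried by a saturated ring carbon of the five-membered non-aromatic ring with two nitrogen and one oxygen: 3-(trifluoromethyl)phenyl in place of 2-(trifluoromethyl)phenyl on a saturated ring carbon. Among the compounds with values here, no measured pair in the set shows how large such a step is, so no direction can be read from the data. The step from compound 1 to compound 4 is expected to be a number 0.2 percentage points higher from compound 1 to compound 4 (within the scatter) in this assay, that is, nothing beyond the scatter. Compound 4 is accordingly estimated to give about 35% in this assay, within a range from 20% to 50%.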

Compound 4, a percentage reported as inhibition, at one concentration (the size of the read-out at that concentration, not a potency): 41.1%
For compound 4 the middle estimate is 6.1 percentage points below the measured one; measured number inside the range.
By their numbers in this assay, from the lowest: compounds 3 and 2 (each within the scatter of the next); then compounds 1 and 4 (each within the scatter of the next).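

In this assay, 3-(trifluoromethyl)phenyl in place of 2-(trifluoromethyl)phenyl on the saturated ring carbon gives a number 6.3 percentage points higher from compound 1 to compound 4 (within the scatter) on the shared core. Within the data shown here, for this pair, then, moving the trifluoromethyl group around the phenyl leaves the read-out unchanged within the scatter, the first such comparison. Nothing available explains this outcome.

Still open, going by these compounds, is whether an amine or a carboxylic acid in place of trifluoromethyl on this phenyl would shift the number beyond the scatter. Also open, on these data alone, is whether a longer chain in place of the acetyl group would do so.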